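Para-fluoro on the benzyl group of compound 3

The source may report more compounds than this note shows. Statements on the series, on what has been measured and on what is new or still open speak of the compounds shown alone.

Of the compounds shown here, three sharing one core have been measured in a functional assay on HL-60 cells (Homo sapiens) for inhibition, read by CCK-8 assay, with a stated time of 48 h, tested at 20 uM; a lower number here means less inhibition of growth, a higher number more inhibition of growth at the concentration tested. Compound 1 `COc1ccc(Cc2nnc(NC(=O)/C(C#N)=C/c3ccccc3OS(=O)(=O)c3ccc(C)cc3)s2)cc1` gives 25%. Compound 2 `Cc1ccc(S(=O)(=O)Oc2ccccc2/C=C(\C#N)C(=O)Nc2nnc(Cc3cccc4ccccc34)s2)cc1` gives 19%. Compound 3 `Cc1ccc(S(=O)(=O)Oc2ccccc2/C=C(\C#N)C(=O)Nc2nnc(Cc3ccccc3)s2)cc1` gives 16%, and the other two values lie within the scatter of it: a number 9 percentage points lower from compound 1 to compound 3 (within the scatter) and a number 3 percentage points lower from compound 2 to compound 3 (within the scatter), as does a number 6 percentage points lower from compound 1 to compound 2 (within the scatter). All three changes touched the group on the saturated chain carbon bound to the aromatic carbon of the core.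

Compound 4 `Cc1ccc(S(=O)(=O)Oc2ccccc2/C=C(\C#N)C(=O)Nc2nnc(Cc3ccc(F)cc3)s2)cc1` differs from compound 3 at that same group: fluoro in place of hydrogen on an aromatic carbon, para to a large group. The step bearing most on it is the one from methoxy to hydrogen at this place, a number 9 percentage points lower from compound 1 to compound 3 (within the scatter), within the scatter; the ring swaps in a number 6 percentage points lower from compound 1 to compound 2 (within the scatter) and a number 3 percentage points lower from compound 2 to compound 3 (within the scatter) were also within the scatter. Since every change here has stayed within the scatter, compound 4 is expected to show a number 2 percentage points higher from compound 3 to compound 4 (within the scatter), no step beyond the scatter. Compound 4 is therefore estimated at 18%, ranging from 8% to 28%.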

Compound 4, percent growth inhibition at one concentration: "not active" (no number reported)
No number was reported for compound 4; the estimate stays without a comparison.
By their numbers in this assay, from the lowest: compounds 3, 2 and 1 (each within the scatter of the next).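

Going by these compounds alone, compound 4 was reported as "not active" with no number, so no step from compound 3 to compound 4 can be read. Nothing measured here bears on this result. The compounds shown leave open whether 4-fluorobenzyl in place of benzyl changes growth inhibition at all.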